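Bromo for Methyl on a Chalcone: One Expected Step

The source may report more compounds than this note shows. Statements on the series, on what has been measured and on what is new or still open speak of the compounds shown alone.

Compound 1 `COc1cc(OC)c(OC)cc1/C=C/C(=O)c1ccc(C)cc1`: 81100 nM
Compound 2 `COc1cc(OC)c(C2CC(=O)c3cc(O)ccc3O2)cc1OC`: > 150000 nM

Among the compounds with values here, in a functional assay on SW982 cells (Homo sapiens) for inhibition, read by MTT assay, with a stated time of 72 h (on this read-out higher numbers stand for weaker inhibition and lower numbers for stronger inhibition), compound 1 gives 81100 nM, the only number among the two values shown. Compound 2 gives only a limit, > 150000 nM, not a number. That is the limit of > 150000 nM in this assay, at which 1 of the 2 values shown sits. Compound 3 `COc1cc(OC)c(OC)cc1/C=C/C(=O)c1ccc(Br)cc1` differs from compound 1 by bromo in place of methyl on an aromatic carbon. Within the data shown here, no step between measured compounds is at hand, so the size of this change cannot be read off and must be expected. For compound 3 the step of a 1.4-fold lower number from compound 1 to compound 3 (0.13 log units; within the scatter) is expected to stay within the usual scatter, in no clear direction. Compound 3 is therefore estimated at about 60000 nM, within 20000 nM to 150000 nM.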

Compound 3, half-maximal inhibitory concentration: 38200 nM
The estimate for compound 3 lay 1.6-fold (0.20 log units) above the measured number; the measured number falls inside the stated range.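

In this assay, bromo in place of methyl gives a 2.1-fold lower number from compound 1 to compound 3 (0.33 log units; beyond the scatter), so this aromatic carbon, para to a large group, is not indifferent to the exchange, although the step is modest. Within the data shown here, this is the first step that can be read at this position. Nothing shown accounts for its size or direction. The compounds shown leave open how chloro, an amine or a carboxylic acid on this carbon would read. They also leave open whether the same exchange would give a similar step on another core.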